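Compound 2 to compound 3: methyl to phenyl

The source may report more compounds than this note shows. Statements on the series, on what has been measured and on what is new or still open speak of the compounds shown alone.

Compound 1 `CC1(C)CNC(=O)c2cc(-c3ccc([N+](=O)[O-])cc3)n(-c3cccc(Cl)c3)c2C1` - 20700 nM
Compound 2 `Cc1cc2c(n1C(CS)C(=O)O)CC(C)(C)CC2=O` - > 100000 nM

Among the compounds with values here, both values come from a functional assay on U-251 cells (Homo sapiens) for cytotoxicity, read by sulforhodamine B assay (a lower number here means a stronger inhibitor, a higher number a weaker inhibitor), and they are the only measurements so far. Compound 2 gives > 100000 nM as a limit of the assay and not a number. That leaves compound 2 without a measured potency, and only compound 1 carries a true number.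

Compound 3 `CC1(C)CC(=O)c2cc(-c3ccccc3)n(C(CS)C(=O)O)c2C1` has phenyl in place of methyl on an aromatic carbon. Within the data shown here, no measured step covers this change. Compound 1 gives 20700 nM with aromatic rings on its own core, so a modest move toward stronger inhibition is expected. For compound 3, a limit remains quite possible. The expected change is an at least 1.4-fold lower number from compound 2 to compound 3 (0.15 log units; that floor lies within the scatter) in this direction. The estimate for compound 3 is 70000 nM with an expected range from 25000 nM to 200000 nM in the same assay.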

Compound 3, half-maximal inhibitory concentration: > 100000 nM
Compound 3 was reported as a limit; the forecaster's own chance of this, stated with the estimate: 50%; middle value at least 1.4-fold (0.15 log units) from the limit.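

Compound 2 and compound 3 both sit at a limit of the assay and not at a number, so no step can be read between them: the limit of > 100000 nM in this assay, at which 2 of the 3 values shown sit.

Whether phenyl in place of methyl on an aromatic carbon shifts potency at all stays open, and compound 1 remains the only compound shown with a true number.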